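Swapping a Cyclopentyl Amide for a Bromobenzylidene Hydrazide

The source may hold more compounds than are shown below. What is called first, only, known or untested is meant among the compounds shown, and "the series" means these compounds.

Measured so far:
compound 1 `Nc1c(C(=O)NC2CCCC2)oc2nc(-c3ccccc3)cc(C(F)(F)F)c12`: 85000 nM
compound 2 `Nc1c(C(=O)N/N=C/c2ccc(Cl)cc2)oc2nc(-c3cccs3)cc(C(F)(F)F)c12`: 83000 nM
compound 3 `CCNC(=O)c1oc2nc(-c3cccs3)cc(C(F)(F)F)c2c1N`: 62000 nM

In an ADME assay on HEK293 cells (Homo sapiens) for antiproliferative activity, read by MTT assay (on this read-out lower numbers stand for stronger inhibition and higher numbers for weaker inhibition), the three numbers all lie within the scatter of one another, with compound 1 at the upper edge of that narrow spread. Compound 4 `Nc1c(C(=O)N/N=C/c2ccc(Br)cc2)oc2nc(-c3ccccc3)cc(C(F)(F)F)c12` differs from compound 1 by a group of 9 heavy atoms (7 carbon, 1 nitrogen, 1 bromine; one six-membered aromatic ring of carbon only) in place of a group of 5 heavy atoms (5 carbon; one five-membered non-aromatic ring of carbon only), on an amide-type nitrogen. Among the measured compounds shown here, the one measured step that bears on this, a 1.3-fold lower number from compound 2 to compound 3 (0.13 log units; within the scatter), also exchanged the group on the amide-type nitrogen and stayed within the scatter, and compound 2, which carries the chloro counterpart of the entering group, sits beside compound 1. The step expected for compound 4 is therefore none beyond the scatter, a 1.1-fold lower number from compound 1 to compound 4 (0.03 log units; within the scatter). Compound 4 is estimated at 80000 nM, with a range from 40000 nM to 160000 nM.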

Compound 4, half-maximal inhibitory concentration: 64000 nM
The estimate for compound 4 lay 1.3-fold (0.10 log units) above the measured number; low and high end bracket the measured number.
By their numbers in this assay, from the lowest: compounds 3, 4, 2 and 1 (each within the scatter of the next).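

In this assay, placing the bromine-bearing group with its six-membered aromatic ring on the amide-type nitrogen in place of cyclopentyl gives a 1.3-fold lower number from compound 1 to compound 4 (0.12 log units; within the scatter). On the core of compound 1, then, this larger exchange does not move the number beyond the scatter, just as the smaller-group exchange on the core of compound 2 did not. No evidence is available that bears on this outcome. On these data alone, whether a longer chain ending in an amine or a carboxylic acid at this nitrogen would move the number beyond the scatter remains open.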